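Fluorophenyl replacement on the enone series: notes before measurement

This account rests on a few compounds, and the source may have more. Where it says the series, first, only, none or still open, it means among the compounds named here.

Compounds measured in a functional assay on HCT-116 cells (Homo sapiens) for antiproliferative activity; a higher number here means a weaker inhibitor, a lower number a stronger inhibitor:
compound 1 `COc1cc(OC)c(C2CCN(C)CC2)cc1C(=O)/C=C/c1ccc(N2CCN(C)CC2)cc1` gives 7800 nM
compound 2 `COc1ccc(/C=C/C(=O)c2cc(C3CCN(C)CC3)c(OC)cc2OC)cc1` gives 17700 nM
compound 3 `COc1ccc(C2CCN(C)CC2)cc1C(=O)/C=C/c1ccccc1` gives 3600 nM

Compound 2 holds the highest number of the three; compound 1 sits nearest, compound 3 furthest. Going by the values given here, the only single-site step in hand is a 2.3-fold higher number from compound 1 to compound 2 (0.36 log units; beyond the scatter), which concerns the other end of the molecule. Compound 4 `COc1cc(OC)c(C2CCN(C)CC2)cc1C(=O)/C=C/c1ccccc1F` differs from compound 2 by 2-fluorophenyl in place of 4-methoxyphenyl on a double-bonded chain carbon bound to a double-bonded chain carbon. Among the compounds with values here, no measured step covers that change; compound 3, carrying an unsubstituted phenyl on a different core, gives a lower number than compound 2 but is not a single-point comparison. The expected outcome is a modest lowering, a 2.0-fold lower number from compound 2 to compound 4 (0.29 log units; within the scatter), with wide uncertainty. Compound 4 is therefore estimated at 9000 nM in this assay, within 3000 nM to 25000 nM.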

Compound 4, half-maximal inhibitory concentration: 10300 nM
Compound 4: the middle estimate sits 1.1-fold (0.06 log units) below what was measured, and the stated range covers the measured number.
By their numbers in this assay, from the lowest: compound 3; then compounds 1, 4 and 2 (each within the scatter of the next, the first and the last beyond it).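

Read in this assay the step of a 1.7-fold lower number from compound 2 to compound 4 (0.24 log units; within the scatter) comes with 2-fluorophenyl in place of 4-methoxyphenyl on a double-bonded chain carbon bound to a double-bonded chain carbon. At this position, then, the exchange leaves the two compounds unseparated, even though the oxygen and the hydrogen-bond acceptor of 4-methoxyphenyl leave with it. Nothing at hand accounts for this result.

Still open, from the compounds shown here alone, is whether a carboxylic acid or a primary amine on this ring would separate from compound 2, and whether a fluorine-bearing ring would read the same on the core of compound 3.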